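The source may hold more compounds than are shown below. What is called first, only, known or untested is meant among the compounds shown, and "the series" means these compounds.

In a functional assay on A498 cells (Homo sapiens) for inhibition, read by sulforhodamine B assay, with a stated time of 48 h (a lower number here means a stronger inhibitor of growth, a higher number a weaker inhibitor of growth), compound 1 `COc1cc(-c2nn(-c3cccc(NC(=O)c4ccc(Cl)c(C(F)(F)F)c4)c3)cc2-c2ccncc2)ccc1Cl` gives 22700 nM. For the measured compounds named here, of the two numbers known, this is the highest, so compound 1 is the weaker of the two measured growth inhibitors. Its nearest neighbour is compound 3 `O=C(Nc1cccc(-n2cc(-c3ccncc3)c(-c3ccc(Cl)c(O)c3)n2)c1)Nc1ccc(Cl)c(C(F)(F)F)c1`, which in this assay gives 6900 nM, a number beyond the scatter below that of compound 1. Compound 2 `O=C(Nc1cccc(-n2cc(-c3ccncc3)c(-c3ccc(Cl)c(O)c3)n2)c1)Nc1cccc(C(F)(F)F)c1` is known in this assay only by a limit, > 32500 nM, so no number is available for it. Going by the values given here, compounds 1 and 3 differ in two places, and their values therefore show only that compound 3 sits lower.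

The compound still to be measured is compound 4 `COc1cc(-c2nn(-c3cccc(NC(=O)Nc4ccc(Cl)c(Cl)c4)c3)cc2-c2ccncc2)ccc1Cl`. ((3,4-dichlorophenyl)amino in place of 4-chloro-3-(trifluoromethyl)phenyl on a carbonyl carbon). Among the compounds with values here, only one measured step bears on this: an at least 4.7-fold lower number from compound 2 to compound 3 (0.67 log units; beyond the scatter). Because one of the three values is the limit of > 32500 nM in this assay, at which 1 of the 3 values shown sits, the true size of that step may be larger than the stated floor. Within the data shown here, no measured pair isolates the change from an amide to a urea on the same core, so that part of the step is unsupported by direct evidence. A modest lowering of the number is expected, resting on the chloro step from compound 2 to compound 3.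

Compound 4 is therefore expected to give about 11000 nM, with a likely range from 4000 nM to 32000 nM. This expectation corresponds to a 2.1-fold lower number from compound 1 to compound 4 (0.31 log units; beyond the scatter), a step estimated to lie just beyond the scatter.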

Compound 4, concentration for total growth inhibition: 4590 nM
Compound 4: the middle estimate sits 2.4-fold (0.38 log units) above what was measured; the range from low to high includes it.
By their numbers in this assay, from the lowest: compounds 4 and 3 (each within the scatter of the next); then compound 1. At a limit, above all of these: compound 2.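

In this assay, the change at this carbonyl carbon gives a 4.9-fold lower number from compound 1 to compound 4 (0.69 log units; beyond the scatter), the first step measured on the core of compound 1. Leaving 4-chloro-3-(trifluoromethyl)phenyl for (3,4-dichlorophenyl)amino does two things at once: it turns the amide into a urea, and it puts a chloro group where the trifluoromethyl group stood. The result shows that these two changes taken together lower the number on this core, beyond the scatter, but it does not show how much each one contributes.

Separating the two would take a urea carrying 4-chloro-3-(trifluoromethyl)phenyl on the core of compound 1, or an amide carrying 3,4-dichlorophenyl on that same core. Also open is how this position would respond to a group of a different kind on that aromatic ring, such as a nitrile, a methoxy group or an amine, in place of the chloro groups, and the compounds shown give no measured step for any of these.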